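A few compounds are considered here, and "the series" means these few. Any claim that something is new, unique, unknown or untested is made for them only; others in the source may bear on it.

Working notes on the series.

Compound 1 `COC(=O)CCCc1onc(NS(=O)(=O)c2ccc(C(C)(C)C)cc2)c1Sc1cccc(OC)c1` and compound 2 `COc1cccc(Sc2c(NS(=O)(=O)c3ccc(C(C)(C)C)cc3)noc2CCO)c1` share one core and differ only at the end of the side chain on that core. In an assay on A7R5 cells for displacement of a labelled ligand from Endothelin-1 receptor (Rattus norvegicus) (on this read-out higher numbers stand for weaker inhibition and lower numbers for stronger inhibition), compound 1 gives 400 nM, and compound 2 gives 770 nM. The step of a 1.9-fold higher number from compound 1 to compound 2 (0.28 log units; within the scatter) therefore stays inside the usual scatter, so the two values cannot be ordered with confidence. Among the two measured compounds compound 2 carries the higher number, though its gap to compound 1 is not beyond the scatter.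

Compound 3 `COc1cccc(Sc2c(NS(=O)(=O)c3ccc(C(C)(C)C)cc3)noc2CO)c1` is the next point in the same place on the core: hydroxy in place of hydroxymethyl on a saturated chain carbon bound to an aromatic carbon. Among the measured compounds shown here, the only measured step that bears on it is the one from compound 1 to compound 2, which also altered this chain and came out as a 1.9-fold higher number from compound 1 to compound 2 (0.28 log units; within the scatter). For the measured compounds named here, no step at this place has yet moved the read-out beyond the scatter, so the expected step of a 1.2-fold higher number from compound 2 to compound 3 (0.07 log units; within the scatter) is taken as small, with no firm direction. For compound 3 in this assay the estimate is 900 nM, with a range from 350 nM to 2500 nM.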

Compound 3, half-maximal inhibitory concentration: 6200 nM
For compound 3 the middle estimate is 6.9-fold (0.84 log units) below the measured one; the measured number lies above the stated range.
By their numbers in this assay, from the lowest: compounds 1 and 2 (each within the scatter of the next); then compound 3.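

Shortening the side chain from 2-hydroxyethyl to hydroxymethyl gives, in this assay, an 8.1-fold higher number from compound 2 to compound 3 (0.91 log units; beyond the scatter) and is the first step at this place to lie beyond the scatter, so this position is not indifferent to the chain after all. The hydroxy end stays in both compounds, which leaves the shorter chain as the only difference, and that small change weakens inhibition far more than the exchange of the ester-bearing chain for 2-hydroxyethyl, which stayed within the scatter. Measured against the ester-bearing chain, the full change is a 16-fold higher number from compound 1 to compound 3 (1.19 log units; beyond the scatter). Compounds 1 and 2 stand together on one side of a clear gap, while no measurement on hand accounts for that gap.

The compounds shown leave open whether inhibition depends on chain length as such or on how far the hydroxy group sits from the core, which a longer chain ending in hydroxy could begin to separate. They also leave open how a carboxylic acid or an amine at the end of the chain would read in this assay.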